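The source may report more compounds than this note shows. Statements on the series, on what has been measured and on what is new or still open speak of the compounds shown alone.

Working notes on the series. The shared core is common to all three measured compounds; they differ only in the aryl group on the amide nitrogen. Compound 1 `Cc1ccc(NC(=O)CSc2nnc(-c3ccoc3C)n2Cc2ccco2)cc1` gives 39.8 nM in a functional assay on CHO cells for antagonist activity at Orexin receptor type 2 (Homo sapiens), read by FLIPR and calcium flux; a lower number here means a stronger inhibitor, a higher number a weaker inhibitor. Compound 2 `Cc1occc1-c1nnc(SCC(=O)Nc2ccc(F)cc2)n1Cc1ccco1` gives 158 nM, and compound 3 `Cc1occc1-c1nnc(SCC(=O)Nc2cccc(Cl)c2)n1Cc1ccco1` gives 63.1 nM. On these numbers compound 3 stands second highest of the three: to compound 1 the gap is a 1.6-fold higher number from compound 1 to compound 3 (0.20 log units; within the scatter), and from compound 2 the step is a 2.5-fold lower number from compound 2 to compound 3 (0.40 log units; beyond the scatter). The step of a 4.0-fold higher number from compound 1 to compound 2 (0.60 log units; beyond the scatter) is the largest seen so far, and all three steps are changes of the substituent on this aryl ring.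

Compound 4 `CC(=O)c1cccc(NC(=O)CSc2nnc(-c3ccoc3C)n2Cc2ccco2)c1` is not yet measured. The change from compound 3 is acetyl in place of chloro on an aromatic carbon. Among the compounds with values here, no measured step involves an acetyl group, so the direction of this change has to be read by analogy with the substituent changes already seen on this ring: 1>2 was modest and 2>3 was modest, while 1>3 stayed within the scatter. A step of similar size in either direction is therefore plausible, with no strong reason to favour one side; the expected step is a 1.3-fold higher number from compound 3 to compound 4 (0.10 log units; within the scatter). Compound 4 is expected to give an estimate of 80 nM in this assay, with a range from 30 nM to 250 nM.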

Compound 4, inhibition constant: 316 nM
Compound 4: the middle estimate sits 4.0-fold (0.60 log units) below what was measured; the measured number lies above the stated range.
By their numbers in this assay, from the lowest: compounds 1 and 3 (each within the scatter of the next); then compounds 2 and 4 (each within the scatter of the next).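

Working notes on this position: in this assay, the aromatic carbon that carries chloro does not treat acetyl as an equivalent group, with a 5.0-fold higher number from compound 3 to compound 4 (0.70 log units; beyond the scatter), a step beyond the scatter. Within the data shown here, the earlier compounds did not show this, since their 3-chlorophenyl and 4-methylphenyl groups stayed within the scatter of each other, and the only earlier step of comparable size came from the 4-fluorophenyl group. The 3-acetylphenyl group also gives a 7.9-fold higher number from compound 1 to compound 4 (0.90 log units; beyond the scatter), beyond the scatter, but a 2.0-fold higher number from compound 2 to compound 4 (0.30 log units; within the scatter), within the scatter, so compound 4 groups with compound 2 rather than with compound 1 and compound 3; no measurement available here explains the step from chloro to acetyl.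

The acetyl group differs from chloro both in its heavy atoms and in its hydrogen-bond acceptor, so the compounds shown do not separate what the carbonyl contributes from what the added carbons contribute. A nitrile, a methoxy group or an amine on this same aromatic carbon, in the otherwise unchanged shared core, would be the next comparisons for reading that difference.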